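Moving the fluorine on the ring amide nitrogen

The source may hold more compounds than are shown below. What is called first, only, known or untested is meant among the compounds shown, and "the series" means these compounds.

Compound 1, `O=C(NCCCCc1ccccc1)c1cccc(C2SCC(=O)N2c2cccc(F)c2)c1`, gives the higher of two numbers in a functional assay on 143B cells (Homo sapiens) for inhibition, read by CCK-8 assay, with a stated time of 72 h, tested at 1 uM; a higher number here means more inhibition at the concentration tested (going by the name of the read-out), a lower number less inhibition: compound 1 gives 63%, while compound 2, `COc1ccccc1N1C(=O)CSC1C(=O)NCCCCc1ccccc1`, gives 4%, a gap that lies beyond the usual scatter. Compound 3, `O=C(NCCCCc1ccccc1)c1cccc(C2SCC(=O)N2c2ccccc2F)c1`, has not yet been measured. It differs from compound 1 in one place: 2-fluorophenyl in place of 3-fluorophenyl on an amide-type nitrogen in a ring. Within the data shown here, no measured pair shows this change. Since compound 1 stands at 63%, the step is expected to be modest and downward, estimated at a number 13 percentage points lower from compound 1 to compound 3 (beyond the scatter). Compound 3 is therefore estimated at 50%, with an expected range from 20% to 75%.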

Compound 3, a percentage reported as inhibition, at one concentration (the size of the read-out at that concentration, not a potency): 59%
Compound 3: the middle estimate sits 9 percentage points below what was measured; the range from low to high includes it.
By their numbers in this assay, from the lowest: compound 2; then compounds 3 and 1 (each within the scatter of the next).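

In this assay, the fluorine on the phenyl ring at the amide-type nitrogen in the ring can go from 3-fluorophenyl to 2-fluorophenyl with a step of a number 4 percentage points lower from compound 1 to compound 3 (within the scatter) in this read-out. With the rest of the core of compound 1 held fixed, these two fluorophenyl groups therefore cannot be told apart here. Nothing available gives a measured reason for this result.

The compounds shown leave open how 4-fluorophenyl or unsubstituted phenyl would fare on this nitrogen. They also leave open whether a pyridine ring could stand in place of the fluorophenyl ring.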